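The source may report more compounds than this note shows. Statements on the series, on what has been measured and on what is new or still open speak of the compounds shown alone.

Working notes on the series. In a physicochemical assay for lipophilicity, at pH 7.4 (a higher number here means a more lipophilic compound, a lower number a more polar compound), compound 1 `CCC(C(=O)O)c1nn(Cc2cn3cc(OCC4CC4)c(Cl)cc3n2)c2ccccc2c1=O` gives 2.71. Compound 2 `CC(C(=O)O)c1nn(Cc2cn3cc(OCC4CC4)c(C(F)(F)F)cc3n2)c2ccccc2c1=O` gives 2.99 in this assay, a number within the scatter of compound 1. Compound 3 `COc1cc(OC)c(NC(=O)Cc2nn(CC(=O)O)c(=O)c3ccccc23)cc1Cl` gives 1.64, a number clearly lower than compound 1, beyond the scatter. Compound 1 thus stands second highest of the three numbers.

Compound 4 `C[C@H](C(=O)O)c1nn(Cc2cn3cc(OCC4CC4)c(Cl)cc3n2)c2ccccc2c1=O` is not yet measured. It differs from compound 1 in one place: 1-carboxyethyl in place of 1-carboxypropyl on an aromatic carbon. Going by the values given here, no step between measured compounds shows this kind of change, so the expectation rests on the change itself. A small downward step is expected, roughly at the edge of the scatter, since one carbon leaves the side chain.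

For compound 4 in this assay a value of 2.3 is estimated, within 1.9 to 2.7, meaning an expected step of a number 0.41 log units lower from compound 1 to compound 4 (beyond the scatter).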

Compound 4, distribution coefficient: 2.39
Compound 4: the middle estimate sits 0.09 log units below what was measured; measured number inside the range.
By their numbers in this assay, from the lowest: compound 3; then compound 4; then compounds 1 and 2 (each within the scatter of the next).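

In this assay, going by these compounds alone, 1-carboxyethyl in place of 1-carboxypropyl on the aromatic carbon next to the ring nitrogen gives the first one-place step, with a number 0.32 log units lower from compound 1 to compound 4 (beyond the scatter) as its size. The same change also brings a defined stereocentre, so this step cannot separate the shorter chain from that stereocentre. No measurement at hand explains the step. Open, as far as these compounds go, are the value of the opposite stereocentre, whether a longer chain such as 1-carboxybutyl moves the number the other way, and what an amine gives at this position.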